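A few compounds are considered here, and "the series" means these few. Any claim that something is new, unique, unknown or untested is made for them only; others in the source may bear on it.

Measured compounds:
compound 1, `OC[C@H]1O[C@@H](n2cnc3c(NCc4ccccc4F)ncnc32)[C@H](O)[C@@H]1O` — in this assay: "not determined" (no result reported)
compound 2, `Cc1cccc(CNc2ncnc3c2ncn3[C@@H]2O[C@H](CO)[C@@H](O)[C@H]2O)c1` — in this assay: > 166000 nM
compound 3, `OC[C@H]1O[C@@H](n2cnc3c(NCc4c(F)ccc(F)c4F)ncnc32)[C@H](O)[C@@H]1O` — in this assay: > 166000 nM

In a functional assay on G-361 cells (Homo sapiens) for antiproliferative activity, with a stated time of 72 h (a lower number here means a stronger inhibitor, a higher number a weaker inhibitor), compound 1 has no recorded number; its entry reads "not determined" (no result reported). Compound 2 reaches only a limit of the assay, > 166000 nM. Compound 3 likewise stops at a limit, > 166000 nM. Within the data shown here, the one step between measured compounds, a step that the two limits leave unreadable from compound 2 to compound 3, therefore cannot be read in either direction. Among the measured compounds shown here, the only evidence in hand is the limit of > 166000 nM in this assay, at which 2 of the 3 values shown sit.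

Compound 4, `COc1cccc(CNc2ncnc3c2ncn3[C@@H]2O[C@H](CO)[C@@H](O)[C@H]2O)c1O`, differs from compound 1 in one place: 2-hydroxy-3-methoxyphenyl in place of 2-fluorophenyl on a saturated chain carbon bound to a nitrogen on an aromatic ring. For the measured compounds named here, no measured step touches this exchange, so nothing in the data fixes its size or direction in this assay. What the shared core has shown so far is two limits, and compound 1 has no number at all to start from. Because the limit of > 166000 nM in this assay, at which 2 of the 3 values shown sit, sets the pattern for the two measured neighbours, compound 4 is expected to land near the weak end of the assay as well, with a considerable chance of another limit rather than a number. For compound 4 the expected value is 100000 nM, within a range of 20000 nM to 200000 nM.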

Compound 4, half-maximal inhibitory concentration: 148000 nM
For compound 4 the middle estimate is 1.5-fold (0.17 log units) below the measured one, within the range that was stated.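

In this assay compound 4 gives 148000 nM, the first number rather than a limit among the compounds shown with a group on this saturated chain carbon bound to a nitrogen on an aromatic ring. The change to 2-hydroxy-3-methoxyphenyl gives an at least 1.1-fold lower number from compound 3 to compound 4 (0.04 log units; that floor lies within the scatter) and an at least 1.1-fold lower number from compound 2 to compound 4 (0.04 log units; that floor lies within the scatter), so neither step yet separates compound 4 from its neighbours beyond the usual scatter. The other two values remain limits of the assay, not numbers: the limit of > 166000 nM in this assay, at which 2 of the 4 values shown sit.

On these data alone, the true size of both steps stays open, and for the exchange itself compound 1 stands at "not determined" (no result reported), which leaves nothing to read from it. As far as these compounds go, whether an amine or a longer chain at this place would give a clearly lower number also stays open.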